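Trading the Chlorobenzyl Amide for a Simple Anilide

A few compounds are considered here, and "the series" means these few. Any claim that something is new, unique, unknown or untested is made for them only; others in the source may bear on it.

In a functional assay on SK-BR-3 cells (Homo sapiens) for cytotoxicity, read by MTT assay, with a stated time of 72 h (a higher number here means a weaker inhibitor, a lower number a stronger inhibitor), compound 1 `N[C@H]1CC[C@H](Nc2c(C(=O)NCc3ccc(F)cc3)nc(N3CCCCC3)c3cccnc23)CC1` reaches only a limit, > 10000 nM. Going by the values given here, compound 2 `N[C@H]1CC[C@H](Nc2c(C(=O)NCc3ccc(Cl)cc3)nc(Br)c3cccnc23)CC1` gives 2000 nM in this assay, the only full number so far, standing beside (the limit of > 10000 nM in this assay, at which 1 of the 2 values shown sits). Compound 3 `N[C@H]1CC[C@H](Nc2c(C(=O)Nc3ccccc3)nc(Br)c3cccnc23)CC1` differs from compound 2 in one place: phenyl in place of 4-chlorobenzyl on an amide-type nitrogen. Among the compounds with values here, no measured pair shows what such a change does here, so the size of the step rests on expectation alone. A modest loss of potency is expected, a 2.3-fold higher number from compound 2 to compound 3 (0.35 log units; beyond the scatter), a little beyond the usual scatter. Compound 3 is therefore estimated at 4500 nM, most likely between 1500 nM and 15000 nM.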

Compound 3, half-maximal inhibitory concentration: 2000 nM
For compound 3 the middle estimate is 2.3-fold (0.35 log units) above the measured one; the range from low to high includes it.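

Phenyl in place of 4-chlorobenzyl on the amide-type nitrogen gives no change at the digits printed from compound 2 to compound 3 (within the scatter) in this assay. Going by these compounds alone, this is the first step read at this position: with the rest of the molecule unchanged, a group of 6 heavy atoms gives the same number as one of 8 heavy atoms, and the chlorine and the carbon lost with it leave no mark on this read-out. Nothing at hand explains this result.

Going by these compounds, how much further this position can be changed remains open. A longer alkyl chain, a pyridine ring or a carboxylic acid on that nitrogen would test whether the read-out stays just as flat.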